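This account rests on a few compounds, and the source may have more. Where it says the series, first, only, none or still open, it means among the compounds named here.

Three compounds of a shared core have been examined in an assay on isolated protein for inhibition of alpha-ketoglutarate-dependent dioxygenase alkB homolog 3 (Homo sapiens), read by polymerase chain reaction, with a stated time of 1 h; on this read-out higher numbers stand for weaker inhibition and lower numbers for stronger inhibition. Compound 1 `Cc1[nH]n(-c2nc3ccccc3n2C)c(=O)c1C` gives > 10000 nM, which is a limit of the assay rather than a number. Compound 3 `Cc1[nH]n(-c2nc3ccccc3[nH]2)c(=O)c1Cc1ccc(Cl)cc1` likewise gives > 10000 nM, again a limit and not a number. Within the data shown here, compound 2 `Cc1[nH]n(-c2nc3cc(C(C)(C)C)ccc3[nH]2)c(=O)c1Cc1ccccc1` gives 640 nM, the only measured number among the three, so compound 2 stands alone at the readable end of this small set; the other two sit at the limit of > 10000 nM in this assay, at which 2 of the 3 values shown sit.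

The next compound, compound 4 `Cc1[nH]n(-c2nc3cc(Cl)ccc3[nH]2)c(=O)c1Cc1ccccc1`, differs from compound 2 in one place: chloro in place of tert-butyl on an aromatic carbon. Among the measured compounds shown here, no step between two measured compounds isolates the effect of this position, so what the change does can only be guessed from the fact that compound 2, which carries the tert-butyl, is the single compound here with a number, while compound 1 and compound 3, which carry neither tert-butyl nor chloro there, give only limits.

On that basis a step in the weaker direction, beyond the usual scatter, is expected for this assay, a 4.7-fold higher number from compound 2 to compound 4 (0.67 log units; beyond the scatter), with a fair chance that only a limit is returned. Compound 4 is accordingly estimated at 3000 nM, in a range from 900 nM to 12000 nM.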

Compound 4, half-maximal inhibitory concentration: 4500 nM
Compound 4: the middle estimate sits 1.5-fold (0.18 log units) below what was measured; low and high end bracket the measured number.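

In this assay, among these compounds, the first step that can be read at this position, chloro in place of tert-butyl on an aromatic carbon, is a 7.0-fold higher number from compound 2 to compound 4 (0.85 log units; beyond the scatter). Among the compounds shown here, this shows that the position is not indifferent to what it carries, since inhibition weakens with this change, yet compound 4 still returns a number rather than a limit, so the tert-butyl is not the only group here that leaves a readable value. Steps to compound 1 and compound 3 cannot be read, and neither compound adds anything on this position, as their values are limits and not numbers: the limit of > 10000 nM in this assay, at which 2 of the 4 values shown sit.

For the compounds shown here, the single pair shows only that the two groups differ, and it cannot say which feature of the exchange accounts for the step, so the order of other groups at this carbon remains open. As far as these compounds go, how an isopropyl, a methoxy, an amine or a carboxylic acid would compare there with tert-butyl and chloro also remains unknown, as does whether the same step would hold with a different group on the benzyl ring of the shared core.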